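A few compounds are considered here, and "the series" means these few. Any claim that something is new, unique, unknown or untested is made for them only; others in the source may bear on it.

Compound 1 `COC(=O)N1N=C(c2ccccc2)CC1c1cc(OC)c(OC)c(OC)c1`, compound 2 `CCOC(=O)N1N=C(c2ccccc2)CC1c1cc(OC)c(OC)c(OC)c1` and compound 3 `CCCOC(=O)N1N=C(c2ccccc2)CC1c1cc(OC)c(OC)c(OC)c1` share one core and differ in a single chain. In a functional assay on MDA-MB-231 cells (Homo sapiens) for antiproliferative activity, read by MTT assay, with a stated time of 48 h (a lower number here means a stronger inhibitor of growth, a higher number a weaker inhibitor of growth), compound 1 gives 1080 nM, compound 2 gives 5610 nM and compound 3 gives 14400 nM. Compound 3 therefore has the highest number of the three and is the weakest inhibitor among them.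

Compound 4 `COc1cc(C2CC(c3ccccc3)=NN2C(=O)OCc2ccccc2)cc(OC)c1OC` carries phenyl in place of ethyl on a saturated chain carbon bound to an oxygen next to a carbonyl group. Among the compounds with values here, no measured step places a ring there, so the evidence is indirect. The nearest guides are the chain extensions, which all raised the number: a 5.2-fold higher number from compound 1 to compound 2 (0.72 log units; beyond the scatter), a 2.6-fold higher number from compound 2 to compound 3 (0.41 log units; beyond the scatter) and, overall, a 13-fold higher number from compound 1 to compound 3 (1.12 log units; beyond the scatter). Each of these lies beyond the scatter. A further modest rise in this assay is therefore expected, although a change no larger than the scatter would not be surprising. The expected change is a 1.4-fold higher number from compound 3 to compound 4 (0.14 log units; within the scatter). The estimate for compound 4 is 20000 nM, with an expected range of 5000 nM to 60000 nM.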

Compound 4, concentration for 50% growth inhibition: > 10000 nM
Compound 4 gave a limit, no number; the forecaster's own chance of this, stated with the estimate: 15%; the middle value is on the limit's open side.
By their numbers in this assay, from the lowest: compound 1; then compound 2; then compound 3.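

In this assay compound 4 gives only a limit, not a number: the limit of > 10000 nM in this assay, at which 1 of the 4 values shown sits. Even so, the benzyloxycarbonyl group, the first with a ring at this position, does not restore the low number of the methyl-bearing compound 1: the result is an at least 9.2-fold higher number from compound 1 to compound 4 (0.96 log units; beyond the scatter), whereas the comparison with the ethyl-bearing compound gives only an at least 1.7-fold higher number from compound 2 to compound 4 (0.25 log units; that floor lies within the scatter). The step from compound 3 cannot be read, so the limit does not show whether phenyl in place of ethyl raises the number further or leaves it unchanged.

The compounds shown leave open how far above the limit the true value of compound 4 lies. They also leave open whether an amine, a carboxylic acid or a substituted phenyl in this place would bring the number back down.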